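Changing the Benzyl Group on a Shared Core

A few compounds are considered here, and "the series" means these few. Any claim that something is new, unique, unknown or untested is made for them only; others in the source may bear on it.

Measured in a functional assay on RAW264.7 cells (Mus musculus) for inhibition, read by Griess assay, with stated times of 2 h and 24 h; a higher number here means a weaker inhibitor, a lower number a stronger inhibitor:
compound 1, `COc1ccc([C@@H]2CC(=O)c3c(O)cc(OCc4cn(Cc5ccc(Cl)cc5)nn4)cc3O2)cc1O`: 17800 nM
compound 2, `COc1ccc([C@@H]2CC(=O)c3c(O)cc(OCc4cn(Cc5cccc(C#N)c5)nn4)cc3O2)cc1O`: 18000 nM
compound 3, `COc1ccc([C@@H]2CC(=O)c3c(O)cc(OCc4cn(Cc5cccc(Cl)c5)nn4)cc3O2)cc1O`: 18200 nM

All three numbers lie within the usual scatter of one another, so compound 3 stands level with compounds 1 and 2 rather than apart from them. Compound 4, `COc1ccc([C@@H]2CC(=O)c3c(O)cc(OCc4cn(Cc5ccccc5C)nn4)cc3O2)cc1O`, differs from compound 3 by 2-methylphenyl in place of 3-chlorophenyl on a saturated chain carbon bound to an aromatic nitrogen. Within the data shown here, the steps that bear on this change are those that swap the group at the same place: a 1.0-fold higher number from compound 1 to compound 3 (0.01 log units; within the scatter) and a 1.0-fold higher number from compound 1 to compound 2 (0.00 log units; within the scatter), with a 1.0-fold higher number from compound 2 to compound 3 (0.00 log units; within the scatter) between the two other variants. Each of these was flat, so the account expects no step beyond the scatter in this assay for compound 4, which means an expected step of a 1.0-fold lower number from compound 3 to compound 4 (0.00 log units; within the scatter). Compound 4 is therefore estimated at 18000 nM, within a range from 9000 nM to 36000 nM.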

Compound 4, half-maximal inhibitory concentration: 13100 nM
The estimate for compound 4 lay 1.4-fold (0.14 log units) above the measured number; measured number inside the range.
By their numbers in this assay, from the lowest: compounds 4, 1, 2 and 3 (each within the scatter of the next).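

In this assay the steps to the 2-methylbenzyl group read a 1.4-fold lower number from compound 3 to compound 4 (0.14 log units; within the scatter) and a 1.4-fold lower number from compound 2 to compound 4 (0.14 log units; within the scatter) and a 1.4-fold lower number from compound 1 to compound 4 (0.13 log units; within the scatter) and all three lie within the scatter. The flat picture at this place therefore holds for a methyl-bearing ring as well, with 2-methylphenyl standing level with 3-chlorophenyl, 3-cyanophenyl and 4-chlorophenyl. Nothing available explains this flatness.
The compounds shown leave open whether an amine or a carboxylic acid on the ring, or a longer chain in place of the benzyl carbon, would give a step beyond the scatter.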